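A Chlorine Added Twice, on Two Different Cores

The source may hold more compounds than are shown below. What is called first, only, known or untested is meant among the compounds shown, and "the series" means these compounds.

Compound 1 `C=C[C@@](C)(/C=C/c1ccc(OCc2cn(Cc3ccccc3)nn2)cc1)CCC=C(C)C` and compound 2 `C=C[C@@](C)(/C=C/c1ccc(OCc2cn(Cc3ccc(Cl)cc3)nn2)cc1)CCC=C(C)C` share one core, and compound 2 carries chloro in place of hydrogen on an aromatic carbon. In a toxicity assay on RAW264.7 cells (Mus musculus) for cytotoxicity, read by MTT assay, with a stated time of 24 h (on this read-out lower numbers stand for stronger inhibition and higher numbers for weaker inhibition), compound 1 gives 480000 nM, while compound 2 gives 327000 nM; the step of a 1.5-fold lower number from compound 1 to compound 2 (0.17 log units; within the scatter). Compound 3 `C=C[C@@](C)(/C=C/c1ccc(OC(=O)c2cc3ccccc3[nH]2)cc1)CCC=C(C)C` rests on another core, and the difference between the two cores is not broken down here. In this assay compound 3 gives 108000 nM, the lowest of the three numbers, beyond the scatter from both others. Compound 4 `C=C[C@@](C)(/C=C/c1ccc(OC(=O)c2cc3cc(Cl)ccc3[nH]2)cc1)CCC=C(C)C` differs from compound 3 by chloro in place of hydrogen on an aromatic carbon. This is the same kind of change as before, not the same: earlier the chloro sat para to a large group, here it sits on a ring that is part of a fused or bridged system of two rings, meta to a fused ring and para to a fused ring. The expected step is a 1.3-fold lower number from compound 3 to compound 4 (0.10 log units; within the scatter), kept small because a 1.5-fold lower number from compound 1 to compound 2 (0.17 log units; within the scatter) stayed within the scatter. For compound 4 the estimate in this assay is 85000 nM, between 35000 nM and 220000 nM.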

Compound 4, half-maximal inhibitory concentration: 110000 nM
Estimate against measurement, compound 4: 1.3-fold (0.11 log units) below; the range from low to high includes it.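

In this assay, placing the chloro on the second core gives a 1.0-fold higher number from compound 3 to compound 4 (0.01 log units; within the scatter), so the 1H-indol-2-yl and 5-chloro-1H-indol-2-yl compounds cannot be told apart here. Set beside the first case, the two steps do not differ: the same change on two cores in this assay, a 1.5-fold lower number (0.17 log units; within the scatter) from compound 1 to compound 2 and a 1.0-fold higher number (0.01 log units; within the scatter) from compound 3 to compound 4, 1.5-fold (0.17 log units) apart, within the scatter of two such steps. This fits the change carrying over from one core to the other, but only as a step too small to read on either core, so it shows no shared effect of the chloro, and two pairs say nothing about further cores.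

The compounds shown leave open whether another group in the same place, such as an amine or a carboxylic acid, would give a step beyond the scatter. They also leave open how a chloro elsewhere on these rings would behave.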